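Swapping the Aryl Group on Compound 1: An Estimate

The source may hold more compounds than are shown below. What is called first, only, known or untested is meant among the compounds shown, and "the series" means these compounds.

Measured so far:
Compound 1 `Cc1cc(O)c(C(C)C)cc1-c1cc(-c2ccccc2Cl)c(C#N)c(=O)[nH]1`; in a functional assay for inhibition, tested at 80 ug/mL (on this read-out higher numbers stand for a stronger effect at the one concentration tested and lower numbers for a weaker effect), compound 1 gives 32%.
Compound 2 `Cc1cc(O)c(C(C)C)cc1-c1cc(-c2cccs2)c(C#N)c(=O)[nH]1`; compound 2 gives 63%.
Compound 3 `COc1cccc(-c2cc(-c3cc(C(C)C)c(O)cc3C)[nH]c(=O)c2C#N)c1`; compound 3 gives 43%.

Compound 1 holds the lowest of the three numbers. The nearest to it is compound 3: a number 11 percentage points higher from compound 1 to compound 3 (beyond the scatter). The furthest is compound 2: a number 31 percentage points higher from compound 1 to compound 2 (beyond the scatter).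

Compound 4 `Cc1cc(O)c(C(C)C)cc1-c1cc(-c2ccc(N(C)C)cc2)c(C#N)c(=O)[nH]1` has not yet been measured. It differs from compound 1 in one place: 4-(dimethylamino)phenyl in place of 2-chlorophenyl on an aromatic carbon.

Both measured steps from compound 1 bear on this one, since each also replaced the 2-chlorophenyl on that aromatic carbon with another ring, and both raised the read-out: a large rise for thiophen-2-yl, a modest rise for 3-methoxyphenyl. The entering 4-(dimethylamino)phenyl is, like 3-methoxyphenyl, a six-membered carbon ring carrying one hydrogen-bond acceptor, so a rise of the modest kind is expected: a number 16 percentage points higher from compound 1 to compound 4 (beyond the scatter). Compound 4 is therefore estimated to give 48% in this assay, with a range from 30% to 68%.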

Compound 4, a percentage reported as inhibition, at one concentration (the size of the read-out at that concentration, not a potency): 66.5%
Compound 4: the middle estimate sits 18.5 percentage points below what was measured; measured number inside the range.
By their numbers in this assay, from the lowest: compound 1; then compound 3; then compounds 2 and 4 (each within the scatter of the next).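

In this assay, the 4-(dimethylamino)phenyl group shows that a six-membered carbon ring at this position can give a large rise (a number 34.5 percentage points higher from compound 1 to compound 4 (beyond the scatter)), and that the choice of ring substituent matters, with a modest rise over the 3-methoxyphenyl group (a number 23.5 percentage points higher from compound 3 to compound 4 (beyond the scatter)). Thiophen-2-yl is also no longer alone at the top of the set, since the two groups cannot be told apart (a number 3.5 percentage points higher from compound 2 to compound 4 (within the scatter)). Nothing available explains these differences.

As far as these compounds go, what remains open is whether the dimethylamino group itself accounts for the rise, which a comparison of plain phenyl, 4-aminophenyl and 4-methoxyphenyl at the same place could help to settle. These are also readings at one concentration, so they leave the potency of all four compounds open.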